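A fluorine added to the piperidine ring of compound 2

A few compounds are considered here, and "the series" means these few. Any claim that something is new, unique, unknown or untested is made for them only; others in the source may bear on it.

Measured compounds:
- Compound 1, `Cn1c(-c2ccc(Cl)cc2)c(CCC(=O)N2CCN(Cc3ccccc3)C(=O)C2)c2cc(Cl)ccc21`: 0.39 nM
- Compound 2, `Cn1c(-c2ccc(Cl)cc2)c(CCC(=O)N2CCC(Cc3ccccc3)CC2)c2cc(Cl)ccc21`: 2.2 nM

Both compounds were tested in an assay on CHO cells with Substance-P receptor (Homo sapiens) as the target; a lower number here means a stronger inhibitor, a higher number a weaker inhibitor. Compound 2 shows the higher of the two numbers; compound 1 gives a number lower by a margin that lies beyond the usual scatter of this assay. Among the measured compounds shown here, no pair of compounds differing in a single place has been measured, so no step size is known from these data.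

Compound 3, `Cn1c(-c2ccc(Cl)cc2)c(CCC(=O)N2CCC(F)(Cc3ccccc3)CC2)c2cc(Cl)ccc21`, has not yet been measured. It differs from compound 2 in one place: fluoro in place of hydrogen on a saturated ring carbon. For the measured compounds named here, with no comparable step to draw on, a change no larger than the usual scatter is expected, in either direction. Compound 3 is therefore expected to give about 2.5 nM, most likely between 0.8 nM and 8 nM. The expected step of a 1.1-fold higher number from compound 2 to compound 3 (0.06 log units; within the scatter) is thus close to nothing.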

Compound 3, half-maximal inhibitory concentration: 0.55 nM
The estimate for compound 3 lay 4.5-fold (0.66 log units) above the measured number, outside the stated range (below it).
By their numbers in this assay, from the lowest: compounds 1 and 3 (each within the scatter of the next); then compound 2.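

In this assay, among the compounds shown here, fluoro in place of hydrogen on a saturated ring carbon, three ring bonds from the ring nitrogen, gives a 4.0-fold lower number from compound 2 to compound 3 (0.60 log units; beyond the scatter) and is the first single-place change that can be read in this set. It shows that the number at this position can move beyond the scatter with the entry of only one heavy atom, one that adds no ring, no hydrogen-bond donors or acceptors, and no net charge. No measurement at hand accounts for this step.

On these data alone, what a hydroxyl group, a methyl group or an amine would do on the same ring carbon stays open, so it is unclear whether this step is particular to fluoro. Also open, as far as these compounds go, is whether fluoro would give a step of similar size in compounds that differ elsewhere.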